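This account rests on a few compounds, and the source may have more. Where it says the series, first, only, none or still open, it means among the compounds named here.

Measured compounds:
compound 1, `Cc1nc(N)sc1CCCN/C(N)=N/C(=O)N[C@@H](C)c1ccccc1`: 1.08
compound 2, `CCCCCCNC(=O)/N=C(\N)NCCCc1sc(N)nc1C`: 0.95
compound 3, `Cc1ccc(C(C)NC(=O)/N=C(\N)NCCCc2sc(N)nc2C)cc1`: 0.85

All three share one core and differ only in the group carried on the amide-type nitrogen. In a functional assay on Right cardiac atrium for agonist activity at histamine H2 receptor (Cavia porcellus), with a stated time of 30 min, in the presence of a further agent that is not named here (on this read-out higher numbers stand for larger maximal responses and lower numbers for smaller maximal responses), compound 3 gives 0.85; this number and that of compound 2 lie within the usual scatter of each other, while compound 1 stands beyond the scatter, higher. Among the measured compounds shown here, the one single-change step measured here is a number 0.13 lower from compound 1 to compound 2 (beyond the scatter), a modest drop when the group on that nitrogen is changed.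

Compound 4, `Cc1nc(N)sc1CCCN/C(N)=N/C(=O)NC(C)c1cccs1`, is not yet measured. It differs from compound 3 by thiophen-2-yl in place of 4-methylphenyl on a saturated chain carbon bound to an amide-type nitrogen and a saturated chain carbon. For the measured compounds named here, no measured step swaps one aromatic ring for another at this place, so the step from compound 3 to compound 4 in this assay is expected to be small: a number 0.050 higher from compound 3 to compound 4 (within the scatter), a change not beyond the scatter. Compound 4 is therefore estimated at 0.9, within a range from 0.75 to 1.05.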

Compound 4, intrinsic activity: the largest response reached, as a fraction of the reference agonist's: 0.88
The estimate for compound 4 lay 0.020 above the measured number, within the range that was stated.
By their numbers in this assay, from the lowest: compounds 3, 4 and 2 (each within the scatter of the next); then compound 1.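

In this assay, the change from 4-methylphenyl to thiophen-2-yl, on a saturated chain carbon bound to an amide-type nitrogen and a saturated chain carbon, gives a number 0.030 higher from compound 3 to compound 4 (within the scatter) and so shows that a five-membered aromatic ring with a sulfur atom can take the place of a six-membered carbon ring with no change beyond the scatter. Against the open-chain hexyl group, 1-(thiophen-2-yl)ethyl gives a number 0.070 lower from compound 2 to compound 4 (within the scatter) and so stays level with it, whereas against 1-phenylethyl it gives a number 0.20 lower from compound 1 to compound 4 (beyond the scatter) and marks compound 1 as standing apart from compound 4. No measurement here accounts for any of these steps.

The groups shown on that nitrogen carry only carbon chains and aromatic rings. On these data alone, how a chain ending in an amine or a carboxylic acid would behave at this place stays open.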